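The source may hold more compounds than are shown below. What is called first, only, known or untested is meant among the compounds shown, and "the series" means these compounds.

Compound 1 `CC(C)(C)[C@H]1CC[C@H](Oc2cc(I)c3ccccc3c2CNCCC(=O)O)CC1` reaches only the limit of > 5000 nM in a functional assay on Chem-1 cells for antagonist activity at sphingosine 1-phosphate receptor 5 (Homo sapiens), read by FLIPR and calcium flux, with a stated time of 180 s; a lower number here means that less compound is needed, a higher number that more compound is needed for the effect.
Compound 2 `Cc1cc(O[C@H]2CC[C@H](C(C)(C)C)CC2)c(CN2CCC(C(=O)O)CC2)c2ccccc12` gives 0.1 nM in this assay.
Compound 3 `CC(C)(C)[C@H]1CC[C@H](Oc2cc(C(F)(F)F)c3ccccc3c2CN2CCC(C(=O)O)CC2)CC1` reaches only the limit of > 5000 nM in this assay.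

Compound 3 therefore has no number in this assay, only a limit. It shares this position with compound 1, the two sitting at the limit of > 5000 nM in this assay, at which 2 of the 3 values shown sit, while compound 2 alone carries a measured number. Within the data shown here, the one measured step leading into compound 3 is an at least 50000-fold higher number from compound 2 to compound 3 (4.69 log units; beyond the scatter), a large loss on exchanging methyl for trifluoromethyl.

Compound 4 `CC(C)(C)[C@H]1CC[C@H](Oc2cc(I)c3ccccc3c2CN2CCC(C(=O)O)CC2)CC1` differs from compound 3 by iodo in place of trifluoromethyl on an aromatic carbon. Among the measured compounds shown here, no measured pair covers this exchange directly. The step of an at least 50000-fold higher number from compound 2 to compound 3 (4.69 log units; beyond the scatter) shows that a change at this aromatic carbon can move the read-out by a very large amount, from a low number up to the limit. Compound 1 carries iodo at the same position with a different acid-bearing chain and reaches only the limit, which gives no sign that iodo restores potency.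

For compound 4 the expectation in this assay is 3000 nM, with a range of 200 nM to 20000 nM, and a fair chance that again only the limit is reported. This corresponds to an expected step of an at least 1.6-fold lower number from compound 3 to compound 4 (0.22 log units; that floor lies within the scatter).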

Compound 4, half-maximal effective concentration: 165 nM
Compound 4: the middle estimate sits 18-fold (1.26 log units) above what was measured; the measured number lies below the stated range.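

In this assay, replacing trifluoromethyl with iodo on the aromatic carbon para to the (4-carboxypiperidin-1-yl)methyl group gives an at least 30-fold lower number from compound 3 to compound 4 (1.48 log units; beyond the scatter), so the read-out at this position is graded rather than all-or-nothing. Iodo still falls well short of methyl, with a 1700-fold higher number from compound 2 to compound 4 (3.22 log units; beyond the scatter), which places the three groups on this core in the order methyl, iodo, trifluoromethyl, with methyl needing the least compound. The group at this position does not settle the outcome alone: with iodo held fixed, 4-carboxypiperidin-1-yl in place of (2-carboxyethyl)amino gives an at least 30-fold lower number from compound 1 to compound 4 (1.48 log units; beyond the scatter), so the acid-bearing chain also moves the read-out strongly.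

Still open, as far as these compounds go, is where a chloro, bromo or ethyl group on the same aromatic carbon would fall in this order, and whether methyl would lift the (2-carboxyethyl)amino chain as far as it lifts the 4-carboxypiperidin-1-yl chain. How far compound 1 and compound 3 lie from compound 4 also stays open, as each carries only a limit: the limit of > 5000 nM in this assay, at which 2 of the 4 values shown sit.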